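The compounds below may be only part of what the source reports. "The series", "measured", "known", "first", "only" and "open" are said of these compounds alone.

Compound 1 is `O=C(NC1CCCNC1)c1ccccc1OCc1ccccc1Cl`. In an assay on lysate for inhibition of phosphatidylcholine:ceramide cholinephosphotransferase 2 (Homo sapiens), read by HPLC, with stated times of 30 min and 2 h (on this read-out lower numbers stand for stronger inhibition and higher numbers for weaker inhibition), compound 1 gives only a limit of the assay, > 100000 nM. Compound 2 is `O=C(Nc1cccnc1)c1ccccc1OCc1ccccc1Cl`, and in this assay compound 2 gives 1100 nM. Compound 3 is `O=C(Nc1cccnc1)c1ccccc1OCc1c(Cl)cccc1Cl`, and in this assay compound 3 gives 690 nM.

Among the two numbers in this assay, compound 2 shows the higher one; compound 3 sits nearest, and the change a 1.6-fold lower number from compound 2 to compound 3 (0.20 log units; within the scatter) stays within the scatter. The third value, that of compound 1, is a limit and not a number.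

Compound 4 is `O=C(Nc1cccnc1)c1ccccc1OCc1ccccc1OCCCCCCl`. It differs from compound 2 in one place: (5-chloropentyl)oxy in place of chloro on an aromatic carbon, on an aromatic carbon of a six-membered aromatic ring of carbon only, ortho to a large group. Going by the values given here, the one measured step on the same ring, a 1.6-fold lower number from compound 2 to compound 3 (0.20 log units; within the scatter), was within the scatter. The other step, an at least 90-fold lower number from compound 1 to compound 2 (1.95 log units; beyond the scatter), was large but changed the group on the amide-type nitrogen, a different place, so it gives no direct guide. Compound 4 is therefore expected to land close to compound 2, with the step of a 1.4-fold higher number from compound 2 to compound 4 (0.13 log units; within the scatter) estimated to stay near the scatter. For compound 4 the estimate in this assay is 1500 nM, expected to fall between 400 nM and 6000 nM.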

Compound 4, half-maximal inhibitory concentration: 670 nM
Compound 4: middle estimate off by 2.2-fold (0.35 log units), on the high side, within the range that was stated.
By their numbers in this assay, from the lowest: compounds 4, 3 and 2 (each within the scatter of the next). At a limit, above all of these: compound 1.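

In this assay, putting (5-chloropentyl)oxy in place of chloro brings 7 heavy atoms instead of 1 and adds 1 hydrogen-bond acceptor, yet the reading barely moves: a 1.6-fold lower number from compound 2 to compound 4 (0.22 log units; within the scatter). The earlier step on this ring only exchanged a hydrogen for a chloro, a change of a single atom, so it could not show how much size this aromatic carbon accepts; this step shows that, for compound 2 and compound 4, a much larger flexible chain can sit there with no change beyond the scatter. Nothing measured here gives a reason why the chain is accepted.

The compounds shown leave open whether the chlorine in the chain matters at all, and how the reading would respond to a chain carrying an amine or a carboxylic acid in its place, or to a longer chain. Also open, from the compounds shown here alone, is whether the same chain would be accepted with piperidin-3-yl rather than pyridin-3-yl on the amide-type nitrogen, the one place where a large step has appeared so far.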